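Changing the aryl group on the amide of compound 2

The source may report more compounds than this note shows. Statements on the series, on what has been measured and on what is new or still open speak of the compounds shown alone.

In an in vitro ADME assay on microsomes from liver (Mus musculus) for pharmacokinetics, read by LC-MS, with a stated time of 10 min, tested at 1 uM (a higher number here means faster removal of the compound, a lower number slower removal), compound 1 `CN1C[C@H](C(=O)Nc2ccc(C#N)cc2)[C@@H](c2ccc(/C=C/C(=O)Nc3ccccc3N)cc2)C1` gives 35 mL/min/kg and compound 2 `Cc1cccc(NC(=O)[C@H]2CN(C)C[C@@H]2c2ccc(/C=C/C(=O)Nc3ccccc3N)cc2)c1` gives 74 mL/min/kg as the higher of the two numbers. Compound 3 `CN1C[C@H](C(=O)Nc2ccc(F)c(Br)c2)[C@@H](c2ccc(/C=C/C(=O)Nc3ccccc3N)cc2)C1` keeps the shared core and differs from compound 2 in one group (3-bromo-4-fluorophenyl in place of 3-methylphenyl on an amide-type nitrogen). Among the compounds with values here, the one measured step at this place is a 2.1-fold higher number from compound 1 to compound 2 (0.33 log units; beyond the scatter) and it is modest. Within the data shown here, no measured compound yet carries 3-bromo-4-fluorophenyl, so that step is the only guide. The expected change is therefore small, a slight fall that stays within the scatter (a 1.5-fold lower number from compound 2 to compound 3 (0.17 log units; within the scatter)). For compound 3 the estimated value is 50 mL/min/kg (25 mL/min/kg to 95 mL/min/kg).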

Compound 3, clearance: 43 mL/min/kg
Compound 3: the middle estimate sits 1.2-fold (0.07 log units) above what was measured; the measured number falls inside the stated range.
By their numbers in this assay, from the lowest: compounds 1, 3 and 2 (each within the scatter of the next, the first and the last beyond it).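

In this assay the new group gives a 1.7-fold lower number from compound 2 to compound 3 (0.24 log units; within the scatter) and also a 1.2-fold higher number from compound 1 to compound 3 (0.09 log units; within the scatter) as its two steps, and both lie within the scatter. So 3-bromo-4-fluorophenyl cannot be told apart from either 3-methylphenyl or 4-cyanophenyl on this amide-type nitrogen, even though those two groups differ from each other beyond the scatter. No measurement available here gives a reason for these numbers. Going by these compounds, all three groups are substituted phenyl rings, so how a pyridine ring or a cyclohexyl group would read at this place remains open.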